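Swapping the hydroxy ester chain for 2-hydroxypropyl

A few compounds are considered here, and "the series" means these few. Any claim that something is new, unique, unknown or untested is made for them only; others in the source may bear on it.

Within the data shown here, in a functional assay on HeLa cells (Homo sapiens) for cytotoxicity, read by MTT assay (on this read-out lower numbers stand for stronger inhibition and higher numbers for weaker inhibition), compound 2 `CCCCC(O)CC(=O)O[C@H](CC=C(C)C)C1=CC(=O)c2c(O)ccc(O)c2C1=O` gives 72200 nM, the higher of the two numbers measured so far. Among the measured compounds shown here, the only other measured compound, compound 1 `CC(C)=CC[C@@H](OC[C@@H](C)O)C1=CC(=O)c2c(O)ccc(O)c2C1=O`, which carries a 2-hydroxypropyl group, gives 22500 nM. Compound 3 `CC(C)=CC[C@@H](OCC(C)O)C1=CC(=O)c2c(O)ccc(O)c2C1=O` is reached from compound 2 by one structural change, 2-hydroxypropyl in place of (2-hydroxyhexyl)carbonyl on an oxygen on a saturated carbon. For the measured compounds named here, one measured step bears on this change, a 3.2-fold higher number from compound 1 to compound 2 (0.51 log units; beyond the scatter), and it is the same exchange run in the opposite direction, so a step of similar size toward a lower number is expected in this assay. This expectation rests on that single pair alone. The expected step is a 3.1-fold lower number from compound 2 to compound 3 (0.50 log units; beyond the scatter). For compound 3 the estimated value is 23000 nM, with an expected range from 11000 nM to 46000 nM.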

Compound 3, half-maximal inhibitory concentration: 24700 nM
Beside the measured number, compound 3's estimate is 1.1-fold (0.03 log units) below it, and the stated range covers the measured number.
By their numbers in this assay, from the lowest: compounds 1 and 3 (each within the scatter of the next); then compound 2.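

In this assay, putting 2-hydroxypropyl in place of (2-hydroxyhexyl)carbonyl on this oxygen gives a 2.9-fold lower number from compound 2 to compound 3 (0.47 log units; beyond the scatter), so the exchange now holds in a second pair and not only in the one that supplied the estimate. The two compounds carrying 2-hydroxypropyl are separated by a 1.1-fold higher number from compound 1 to compound 3 (0.04 log units; within the scatter), which means that the drawn configuration at this chain stereocentre leaves the number within the scatter in this pair, and the only difference between them is this: the fact that one of compounds 1 and 3 is drawn with a defined configuration and the other without, at the place where they differ

The compounds shown do not separate the length of the chain from the presence of the carbonyl, since the change alters both at once; a hexyl ether or a short acetyl ester on the same oxygen would pull the two apart. Going by these compounds, how the opposite configuration alone would read also stays open.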